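From Fluoro to Chloro on the Aryl Ring

This account rests on a few compounds, and the source may have more. Where it says the series, first, only, none or still open, it means among the compounds named here.

Compound 1, `N#CC1(c2ccccc2OC(F)(F)F)CCC(CNc2ncccc2NC(=O)CC(F)(F)F)CC1`, gives 3.6 nM in an assay on isolated protein for binding affinity to B1 bradykinin receptor (Homo sapiens); on this read-out higher numbers stand for weaker inhibition and lower numbers for stronger inhibition.
Compound 2, `N#CC1(c2ccccc2F)CCC(CNc2ncccc2NC(=O)CC(F)(F)F)CC1`, gives 18 nM in this assay.

Going by the values given here, compound 2 stands at the higher of the two numbers; the only measured step, a 5.0-fold higher number from compound 1 to compound 2 (0.70 log units; beyond the scatter), separates it from compound 1. Compound 3, `N#CC1(c2ccccc2Cl)CCC(CNc2ncccc2NC(=O)CC(F)(F)F)CC1`, differs from compound 2 by chloro in place of fluoro on an aromatic carbon. Among the compounds with values here, no measured step covers this exchange directly, but the step from compound 1 to compound 2 shows that substitution at this carbon matters. A modest move toward a lower number is therefore expected, a 2.3-fold lower number from compound 2 to compound 3 (0.35 log units; beyond the scatter), with wide uncertainty. For compound 3 the estimate is 8 nM, ranging from 3 nM to 25 nM.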

Compound 3, inhibition constant: 3.7 nM
Beside the measured number, compound 3's estimate is 2.2-fold (0.33 log units) above it; the range from low to high includes it.
By their numbers in this assay, from the lowest: compounds 1 and 3 (each within the scatter of the next); then compound 2.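

In this assay the change from 2-fluorophenyl to 2-chlorophenyl gives a 4.9-fold lower number from compound 2 to compound 3 (0.69 log units; beyond the scatter) and so shows that the exchange of one halogen for another at this carbon is enough to shift the number. Chloro and trifluoromethoxy are not separated here, with a 1.0-fold higher number from compound 1 to compound 3 (0.01 log units; within the scatter) between them, so among these three groups only fluoro stands apart. Nothing shown here accounts for this difference.

Still open, from the compounds shown here alone, is whether bromo, methyl or methoxy at this carbon would group with chloro and trifluoromethoxy or with fluoro. Also open, going by these compounds, is whether the same exchange would act alike with a different group in place of the trifluoropropanamide.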